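A few compounds are considered here, and "the series" means these few. Any claim that something is new, unique, unknown or untested is made for them only; others in the source may bear on it.

For the measured compounds named here, compound 3, with the structure `CC(C)C(/C=C1\NC(=O)NC1=O)c1ccc(-c2ccc3cccc(F)c3c2)[nH]c1=O`, is the only compound here that gives a number in an ADME assay on microsomes from liver (Rattus norvegicus) for metabolic stability; a lower number here means that the compound disappears faster, a higher number that the compound lasts longer: compound 3 gives 1.46 h. Compound 1, with the structure `C/C(=C1/OC(=O)NC1=O)C(c1ccc(-c2ccc3cccc(F)c3c2)[nH]c1=O)C(C)C`, reaches a limit of the assay, giving > 3 h. Compound 2, with the structure `CC(C)C(/C=C1\OC(=O)NC1=O)c1cc(Cl)c(-c2ccc3cccc(F)c3c2)[nH]c1=O`, likewise reaches a limit, giving > 3 h. Compound 3 thus stands below (the limit of > 3 h in this assay, at which 2 of the 3 values shown sit).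

Compound 4 has the structure `CC(C)C(CC1C(=O)NC(=O)N1C)c1ccc(-c2ccc3cccc(F)c3c2)[nH]c1=O`. Between compound 3 and compound 4 the change is a group of 9 heavy atoms (5 carbon, 2 nitrogen, 2 oxygen; one five-membered non-aromatic ring with 2 hetero atoms) in place of a group of 8 heavy atoms (4 carbon, 2 nitrogen, 2 oxygen; one five-membered non-aromatic ring with 2 hetero atoms), on a saturated chain carbon bound to an aromatic carbon and a saturated chain carbon.

Going by the values given here, only one measured step exists, and it concerns a different group on the same saturated chain carbon: an at least 2.0-fold lower number from compound 1 to compound 3 (0.31 log units; beyond the scatter). That step does not involve the (3-methyl-2,5-dioxoimidazolidin-4-yl)methyl group that enters in compound 4, so it bears on the present change only loosely. Compound 4 is therefore expected to sit near compound 3, with a modest rise at most, as a step of a 1.4-fold higher number from compound 3 to compound 4 (0.14 log units; within the scatter). The estimate for compound 4 in this assay is 2 h, within a range from 1 h to 4 h.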

Compound 4, half-life: < 0.0667 h
Compound 4: a limit, no number; the forecaster's own chance of this, stated with the estimate: 30%; middle value at least 29-fold (1.47 log units) from the limit.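

At this saturated chain carbon, bringing in the (3-methyl-2,5-dioxoimidazolidin-4-yl)methyl group produces an at least 21-fold lower number from compound 3 to compound 4 (1.34 log units; beyond the scatter) and an at least 44-fold lower number from compound 1 to compound 4 (1.65 log units; beyond the scatter) in this assay, so a change at this place can shorten the half-life by a large step, not only a modest one. Compound 4 gives < 0.0667 h, which is a limit of the assay and not a number. Compound 4 therefore sits at the low end of what the assay reports: the limit of < 0.0667 h in this assay, at which 1 of the 4 values shown sits.

The entering group differs from the leaving one in its double bonds, its hydrogen-bond donors and its heavy atoms all at once, and the compounds shown cannot tell which of these differences goes with the drop. As far as these compounds go, how an amine or a carboxylic acid at this place would behave also remains open.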